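A few compounds are considered here, and "the series" means these few. Any claim that something is new, unique, unknown or untested is made for them only; others in the source may bear on it.

Among the compounds with values here, the three compounds measured so far share one core and differ only in the group carried on the nitrogen on an aromatic ring. In an ADME assay on HepG2 2.2.15 cells (Homo sapiens) for cytotoxicity (a lower number here means that less compound is tolerated, a higher number that more compound is tolerated), compound 1 `CC(C)(C)C(=O)Nc1ncc(C(Oc2ccc3cc(Br)ccc3c2)c2ccc(Cl)cc2)s1` is recorded as "not toxic" (no number reported), with no number given. Compound 2 `COc1ccc(C(=O)Nc2ncc(C(Oc3ccc4cc(Br)ccc4c3)c3ccc(Cl)cc3)s2)cc1` reaches only a limit of the assay in this assay, at > 50000 nM. Compound 3 `N#Cc1cccc(C(=O)Nc2ncc(C(Oc3ccc4cc(Br)ccc4c3)c3ccc(Cl)cc3)s2)c1` likewise gives only a limit in this assay, at > 50000 nM. Compound 3 thus stands at the upper edge of what the assay reports, in the same place as the other two. The step that the two limits leave unreadable from compound 2 to compound 3 cannot be sized, as the limit of > 50000 nM in this assay, at which 2 of the 3 values shown sit, shows. Compound 4 `Cc1ccc(C)c(S(=O)(=O)Nc2ncc(C(Oc3ccc4cc(Br)ccc4c3)c3ccc(Cl)cc3)s2)c1` differs from compound 3 by (2,5-dimethylphenyl)sulfonyl in place of (3-cyanophenyl)carbonyl on a nitrogen on an aromatic ring. Within the data shown here, no measured step covers a change of this kind, and the one measured step is unreadable, so the numbers give no ground to expect a move in this assay beyond the scatter. Compound 4 is expected to sit at 50000 nM, within 20000 nM to 100000 nM, most likely again reported only as a limit. The step of a number no higher from compound 3 to compound 4 (the limit leaves the size open) is therefore estimated to be flat.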

Compound 4, half-maximal cytotoxic concentration: > 50000 nM
Compound 4: no number, only a limit; the forecaster's own chance of this, stated with the estimate: 70%; the middle value lies on the limit itself.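

The steps from compound 2 and from compound 3 to compound 4 cannot be read, because all three compounds give only a limit in this assay: the limit of > 50000 nM in this assay, at which 3 of the 4 values shown sit. The compounds shown leave open what concentration of any of them would harm the cells, and whether the (2,5-dimethylphenyl)sulfonyl group changes it.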